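Bromo to methoxy on compound 1

A few compounds are considered here, and "the series" means these few. Any claim that something is new, unique, unknown or untested is made for them only; others in the source may bear on it.

compound 1 `CC1(c2ccc(NC(c3ccc(Br)cc3)c3nnnn3C(C)(C)C)cc2)NC(=O)c2ccccc2N1`: 400000 nM
compound 2 `CC1(c2ccc(NC(c3ccc(Br)cc3)c3nnnn3C3CCCCC3)cc2)NC(=O)c2ccccc2N1`: > 400000 nM (a limit)
compound 3 `CCCCCNC(c1ccc(C2NC(=O)c3ccccc3N2)cc1)c1nnnn1C(C)(C)C`: "not determined" (no result reported)

Going by the values given here, in an ADME assay on J774.A1 cells (Mus musculus) for cytotoxicity, read by MTT assay, with a stated time of 72 h (a higher number here means that more compound is tolerated, a lower number that less compound is tolerated), compound 1 holds the only actual number, 400000 nM, in this small set. Compound 2 reaches only a limit, and compound 3 has no result. Compound 4 `COc1ccc(C(Nc2ccc(C3(C)NC(=O)c4ccccc4N3)cc2)c2nnnn2C(C)(C)C)cc1` carries methoxy in place of bromo on an aromatic carbon, para to a large group. Among the compounds with values here, the one measured step, a number no lower from compound 1 to compound 2 (the limit leaves the size open), lies at another place and has no readable size, so it bears only loosely on this change. No step beyond the usual scatter is therefore expected, and the estimate rests on compound 1 at 400000 nM as its starting point. The estimate for compound 4 is 400000 nM, with an expected range from 180000 nM to 800000 nM as its limits. This expectation amounts to no change at the digits printed from compound 1 to compound 4 (within the scatter) in this assay as the estimated step.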

Compound 4, half-maximal cytotoxic concentration: > 400000 nM
Compound 4: a limit, no number (the forecaster's own chance of this, stated with the estimate: 45%); the middle value sits exactly at the limit.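

Replacing bromo with methoxy on the aromatic carbon para to a large group gives a number no lower from compound 1 to compound 4 (the limit leaves the size open). Going by these compounds alone, this is the only measured step at this place, since the earlier step lay elsewhere, and in this assay it brings no lower number. Its size cannot be read, and the limit recurs within this small set: the limit of > 400000 nM in this assay, at which 2 of the 4 values shown sit. Going by these compounds, how an amine or a carboxylic acid at this place would read in this assay stays open. So does whether methoxy gives the same result with cyclohexyl on the aromatic nitrogen.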